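The compounds below may be only part of what the source reports. "The series", "measured", "known", "first", "only" and "open" are said of these compounds alone.

Measured so far:

Compound 1, `Cn1ncc2c1NC(=O)CN=C2c1ccccc1`, in a functional assay on the whole organism (strain Holtzman) with Rattus norvegicus as the target (a higher number here means that more compound is needed for the effect, a lower number that less compound is needed), gives > 80 mg/kg, which is a limit of the assay and not a number.
Compound 2, `Cc1nn(C)c2c1C(c1cccc(Cl)c1)=NCC(=O)N2`, in this assay gives > 40 mg/kg, again a limit of the assay.
Compound 3, `CCc1nn(C)c2c1C(c1ccc(F)cc1)=NCC(=O)N2`, in this assay gives > 40 mg/kg, again a limit of the assay.

Compound 1 therefore stands nowhere on a scale of numbers: its value is a limit, and the two other values shown are limits as well. The two limits are described by the limit of > 80 mg/kg in this assay, at which 1 of the 3 values shown sits, where compound 1 sits, and (the limit of > 40 mg/kg in this assay, at which 2 of the 3 values shown sit), where compound 2 and compound 3 sit. For the measured compounds named here, no pair of measured compounds differs in just one place, so no measured step exists here.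

Compound 4 is `Cn1nc(Cl)c2c1NC(=O)CN=C2c1ccccc1`. It differs from compound 1 in one place: chloro in place of hydrogen on an aromatic carbon.

Nothing measured here shows any single change moving a value off a limit. Because the limit of > 40 mg/kg in this assay, at which 2 of the 3 values shown sit, and the limit of > 80 mg/kg in this assay, at which 1 of the 3 values shown sits, hold all three values shown, compound 4 is expected to stay near where compound 1 sits, with a step of a number no higher from compound 1 to compound 4 (the limit leaves the size open) expected to be none beyond the usual scatter. Compound 4 is estimated at 80 mg/kg, in a range from 20 mg/kg to 320 mg/kg, most likely reported as a limit again.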

Compound 4, minimum effective dose: 40 mg/kg
Compound 4: the middle estimate sits 2.0-fold (0.30 log units) above what was measured; the range from low to high includes it.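

In this assay, for the compounds shown here, compound 4 gives 40 mg/kg, the only value shown that is a number and not a limit, so a single chloro on this aromatic carbon, next to the ring nitrogen, is enough to bring a minimum effective dose into reach on the core of compound 1. Compound 1 stands at > 80 mg/kg, which is a limit of the assay and not a number. Chloro in place of hydrogen therefore gives an at least 2.0-fold lower number from compound 1 to compound 4 (0.30 log units; that floor lies within the scatter), so the true gain could be much larger, yet what can be read with certainty does not by itself rise out of the scatter.

The size of the step stays open, since the dose that compound 1 would need is unknown, and the compounds shown give no reason why chloro at this position has this result. Whether another single group here, such as bromo, methoxy or an amine, would also give a number, or a lower one than compound 4, also stays open, and no other pair shown differs in just one place to help decide it.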